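Swapping a thiazolylamino arm for a carbamoylmethyl arm

A few compounds are considered here, and "the series" means these few. Any claim that something is new, unique, unknown or untested is made for them only; others in the source may bear on it.

Compound 1 `CC(C)C(Nc1nccs1)c1ccc(-c2ccc3cccc(F)c3c2)[nH]c1=O`: 9.4 nM
Compound 2 `CCn1ncc2c(F)cc(-c3ccc(C(CC)(CC)c4ncn(C)n4)c(=O)[nH]3)cc21`: 39 nM
Compound 3 `CCn1ncc2c(C)cc(-c3ccc([C@@]4(C)CCNC4=O)c(=O)[nH]3)cc21`: 5 nM

All three were tested in an assay on CHO cells for displacement of a labelled ligand from prostaglandin E2 receptor EP3 subtype (Homo sapiens), read by radioligand binding; on this read-out lower numbers stand for stronger inhibition and higher numbers for weaker inhibition. Compound 1 gives the second highest number of the three; compound 3 is nearest, with a number that sits within the scatter of that of compound 1, while compound 2 has the highest number and lies beyond the scatter. Compound 4 `CC(C)C(CC(N)=O)c1ccc(-c2ccc3cccc(F)c3c2)[nH]c1=O` is not yet measured. It differs from compound 1 in one place: carbamoylmethyl in place of (1,3-thiazol-2-yl)amino on a saturated chain carbon bound to an aromatic carbon and a saturated chain carbon. Going by the values given here, no measured pair shows this exact change, so the size of the step is uncertain. The expectation is a moderate weakening in this assay, a step beyond the scatter but not a large one. Compound 4 is estimated at 50 nM, with a range from 10 nM to 300 nM, which is an expected step of a 5.3-fold higher number from compound 1 to compound 4 (0.73 log units; beyond the scatter).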

Compound 4, inhibition constant: 5 nM
For compound 4 the middle estimate is 10-fold (1.00 log units) above the measured one; the whole stated range lies above it.
By their numbers in this assay, from the lowest: compounds 3, 4 and 1 (each within the scatter of the next); then compound 2.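

In this assay carbamoylmethyl in place of (1,3-thiazol-2-yl)amino gives a 1.9-fold lower number from compound 1 to compound 4 (0.27 log units; within the scatter) and so leaves the number within the scatter. On this saturated chain carbon, then, binding at this level does not depend on keeping the five-membered aromatic ring, and a smaller group with no ring serves as well. Nothing measured here explains why the two groups read alike.

Still open, on these data alone, is how an amine, a carboxylic acid or a longer chain ending in the same amide would read on this carbon. A single pair also cannot show whether this swap would give a similar step on another core.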